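Aryl swap on the amide nitrogen: compound 1 to compound 4

The compounds below may be only part of what the source reports. "The series", "measured", "known", "first", "only" and "open" are said of these compounds alone.

Measured so far:
compound 1 `COc1ccc(C(=O)Nc2c(F)cccc2Cl)cc1OC1CCCC1` gives 240 nM
compound 2 `COc1ccc(C(=O)Nc2ccccc2Cl)cc1OC(=O)c1ccccc1` gives > 1000000 nM
compound 3 `COc1ccc(/C(S)=N/c2ccccc2Cl)cc1OC1CCCC1` gives 200 nM

In an assay on isolated protein for inhibition of phosphodiesterase 4A (Sus scrofa) (a higher number here means a weaker inhibitor, a lower number a stronger inhibitor), compound 1 gives 240 nM and compound 3 gives 200 nM; the two numbers lie within the usual scatter of each other, so nothing separates them. Compound 2 sits at the limit of > 1000000 nM in this assay, at which 1 of the 3 values shown sits, which is a limit of the assay and not a number. Among the two numbers shown, compound 1 holds the higher one, with compound 3 close beside it inside the scatter.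

Compound 4 `COc1ccc(C(=O)Nc2c(C)nsc2C)cc1OC1CCCC1` has not yet been measured in this assay. It differs from compound 1 in one place: 3,5-dimethyl-1,2-thiazol-4-yl in place of 2-chloro-6-fluorophenyl on an amide-type nitrogen. Going by the values given here, no measured pair shows a change of this kind, so the expected size of the step rests on the structural change alone and on the value of compound 1. The step from compound 1 to compound 4 is expected to be small, toward a somewhat higher number, a 1.7-fold higher number from compound 1 to compound 4 (0.22 log units; within the scatter), and not clearly beyond the scatter. Compound 4 is estimated at 400 nM, with a range from 100 nM to 1600 nM.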

Compound 4, half-maximal inhibitory concentration: 500 nM
The estimate for compound 4 lay 1.3-fold (0.10 log units) below the measured number; the measured number falls inside the stated range.
By their numbers in this assay, from the lowest: compounds 3 and 1 (each within the scatter of the next); then compound 4. At a limit, above all of these: compound 2.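

Replacing 2-chloro-6-fluorophenyl with 3,5-dimethyl-1,2-thiazol-4-yl on an amide-type nitrogen gives a 2.1-fold higher number from compound 1 to compound 4 (0.32 log units; beyond the scatter) in this assay, a modest loss. The earlier compounds shown here carried only a six-membered aromatic ring of carbon at this place, whereas this pair shows that a five-membered aromatic ring with 2 hetero atoms keeps inhibition measurable, at a small cost. Nothing measured here accounts for the size of this step.

From the compounds shown here alone, it remains open whether the two methyl groups or the ring atoms of the 1,2-thiazole carry the effect, which the unsubstituted 1,2-thiazol-4-yl or a 3,5-dimethylisoxazol-4-yl group on the same nitrogen would address. Also open, going by these compounds, is how a saturated group such as cyclohexyl, or a 2-aminoethyl chain, would behave at this place.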